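From 3-chlorophenyl to 2-phenylethenyl on a shared core

The source may report more compounds than this note shows. Statements on the series, on what has been measured and on what is new or still open speak of the compounds shown alone.

Values measured in a functional assay on SMMC-7721 cells (Homo sapiens) for cytotoxicity, read by MTT assay, with a stated time of 72 h (on this read-out lower numbers stand for stronger inhibition and higher numbers for weaker inhibition), for the three compounds:
- compound 1 `CN(C)c1ccc(C=C2C(=O)N(c3ccc(Cl)cc3)N(c3ccc(Cl)cc3)C2=O)cc1` gives > 128000 nM (a limit, not a number)
- compound 2 `COc1ccc(C=C2C(=O)N(c3ccc(Cl)cc3)N(c3ccc(Cl)cc3)C2=O)cc1` gives > 128000 nM (a limit, not a number)
- compound 3 `O=C1C(=Cc2cccc(Cl)c2)C(=O)N(c2ccc(Cl)cc2)N1c1ccc(Cl)cc1` gives 20200 nM (a true number)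

Compound 3 is the only one of the three with a true number. The other two stop at the limit of > 128000 nM in this assay, at which 2 of the 3 values shown sit, and give only that limit.

Compound 4 `O=C1C(=C/C=C/c2ccccc2)C(=O)N(c2ccc(Cl)cc2)N1c1ccc(Cl)cc1` is not yet measured. It carries 2-phenylethenyl in place of 3-chlorophenyl on a double-bonded chain carbon bound to a double-bonded ring carbon.

Two measured steps changed this same place, an at least 6.3-fold lower number from compound 1 to compound 3 (0.80 log units; beyond the scatter) and an at least 6.3-fold lower number from compound 2 to compound 3 (0.80 log units; beyond the scatter) in the same direction. Neither brought in 2-phenylethenyl, so they show that this place can move the number but not how far this new group will move it. Compound 4 is therefore expected to stay near compound 3 at 20200 nM as the only firm anchor. The estimated step is a 1.5-fold higher number from compound 3 to compound 4 (0.17 log units; within the scatter) and none beyond the scatter is expected, though a reading at the limit remains possible. For compound 4 the estimate is 30000 nM within an expected range from 9000 nM to 110000 nM (the limit stays possible).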

Compound 4, half-maximal inhibitory concentration: 10100 nM
Compound 4: the middle estimate sits 3.0-fold (0.47 log units) above what was measured, and the stated range covers the measured number.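

Putting 2-phenylethenyl at this place gives a 2.0-fold lower number from compound 3 to compound 4 (0.30 log units; within the scatter), so the new group and 3-chlorophenyl cannot be told apart here, and a phenyl ring carried on an extra double bond serves as well as a chlorinated ring. Against the other two groups it gives an at least 12-fold lower number from compound 2 to compound 4 (1.10 log units; beyond the scatter) and an at least 12-fold lower number from compound 1 to compound 4 (1.10 log units; beyond the scatter). Both steps are minimum sizes, because two compounds reach a limit of the assay: the limit of > 128000 nM in this assay, at which 2 of the 4 values shown sit.

Whether the added double bond matters remains open, since a saturated 2-phenylethyl chain is not among the compounds shown. Also open, on these data alone, is what an amine or a carboxylic acid would do at this place.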